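The compounds below may be only part of what the source reports. "The series", "measured", "known", "first", "only" and "open" are said of these compounds alone.

Measured compounds:
compound 1, `CCCCCCCCS(=O)(=O)Nc1cc(-c2ccccc2-c2ccccc2)ccc1C(=O)O`, 17100 nM
compound 2, `CCCCCCCCS(=O)(=O)Nc1ccc(-c2ccccc2Cl)cc1C(=O)O`, 14400 nM

Both were tested in an assay on mitochondria (strain BALB/c) for inhibition of glycerol-3-phosphate acyltransferase 1, mitochondrial (Mus musculus), read by scintillation counting, with a stated time of 10 min; on this read-out higher numbers stand for weaker inhibition and lower numbers for stronger inhibition. Compound 1 gives 17100 nM, and compound 2 gives 14400 nM. The two numbers lie within the scatter of each other, so neither compound is set apart. Compound 3, `CCCCCCCCS(=O)(=O)Nc1ccc(-c2ccc(CCCC)cc2)cc1C(=O)O`, has not been measured yet. It is reached from compound 2 by one change: 4-butylphenyl in place of 2-chlorophenyl on an aromatic carbon. Among the measured compounds shown here, no step between measured compounds is available to show how an exchange of this kind moves the numbers in this assay, so any expectation rests on compound 2 alone. Both measured compounds sit in the same weak range, and a step beyond the scatter in either direction cannot be expected with confidence, although a modest move toward stronger inhibition is as plausible as none. Compound 3 is expected to give about 10000 nM, with a range from 3000 nM to 30000 nM, which corresponds to an expected step of a 1.4-fold lower number from compound 2 to compound 3 (0.16 log units; within the scatter).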

Compound 3, half-maximal inhibitory concentration: 9000 nM
Beside the measured number, compound 3's estimate is 1.1-fold (0.05 log units) above it; low and high end bracket the measured number.
By their numbers in this assay, from the lowest: compounds 3, 2 and 1 (each within the scatter of the next).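

In this assay, the exchange of 2-chlorophenyl for 4-butylphenyl on this aromatic carbon gives a 1.6-fold lower number from compound 2 to compound 3 (0.20 log units; within the scatter), so compound 2 and compound 3 cannot be told apart. Among the compounds shown here, this position therefore accepts a group of 10 heavy atoms in place of one of 7 with no change that stands out from the scatter, which the earlier compounds could not show because no step between them was available. Nothing measured here explains this result.

Going by these compounds, whether a phenyl group carrying an amine or a carboxylic acid, or a chain longer than butyl, would move the number beyond the scatter at this position stays open. On these data alone, the exchange also removes the chlorine and adds the butyl chain in one step, so the contribution of each remains unknown.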